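The source may hold more compounds than are shown below. What is called first, only, known or untested is meant among the compounds shown, and "the series" means these compounds.

Compound 1, `CC(C)CSc1nc(N)nc2c1ncn2/C=C1/CC1(CO)CO`, gives > 20000 nM in an ADME assay on Akata cells (Homo sapiens) for cytotoxicity, with a stated time of 7 days; on this read-out lower numbers stand for higher toxicity in this test and higher numbers for lower toxicity in this test. Compound 2, `CC(C)Nc1nc(N)nc2c1ncn2/C=C1/CC1(CO)CO`, gives > 24000 nM in this assay.

In this assay compound 2 stands at a limit of the test, not at a measured number. Compound 1 likewise sits at a limit in this assay. Within the data shown here, the only measured step, a step that the two limits leave unreadable from compound 1 to compound 2, therefore cannot be read for size, because both of its ends are limits, as the evidence the limit of > 20000 nM in this assay, at which 1 of the 2 values shown sits, and the limit of > 24000 nM in this assay, at which 1 of the 2 values shown sits, records.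

Compound 3, `CCCOc1nc(N)nc2c1ncn2/C=C1/CC1(CO)CO`, differs from compound 2 by propoxy in place of isopropylamino on an aromatic carbon. Among the measured compounds shown here, no measured step addresses this exchange directly. The one step shown, a step that the two limits leave unreadable from compound 1 to compound 2, also exchanged a group on an aromatic carbon of the shared core, and it left both compounds at limits. With both measured compounds at limits, no step beyond the scatter is expected in this assay in either direction.

Compound 3 is accordingly expected to remain at a limit, estimated at 25000 nM with a range from 12000 nM to 50000 nM. The step this estimate means, a step that the limit leaves unreadable from compound 2 to compound 3, is expected to lie within the scatter.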

Compound 3, half-maximal cytotoxic concentration: > 20000 nM
Compound 3: only a limit was reported; the forecaster's own chance of this, stated with the estimate: 85%; the middle value does not contradict the limit.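

In this assay compound 3 gives > 20000 nM, which is a limit of the test. Among these compounds, no step among compound 1, compound 2 and compound 3 can be read for size, because all three stand at limits: the limit of > 20000 nM in this assay, at which 2 of the 3 values shown sit. The compounds shown leave open whether propoxy, isopropylamino and isobutylsulfanyl on the shared core differ at all in this assay.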